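This account rests on a few compounds, and the source may have more. Where it says the series, first, only, none or still open, it means among the compounds named here.

Working notes on the series, read in a functional assay on MIA PaCa-2 cells (Homo sapiens) for inhibition, read by MTT assay, with a stated time of 48 h, tested at 10 uM; a higher number here means more inhibition of growth at the concentration tested, a lower number less inhibition of growth. Compound 1 `Cc1oc2c([C@H]3CCN(C)C[C@H]3O)c(O)cc(O)c2c(=O)c1C(O)c1ccccc1Br` gives 10% and compound 2 `Cc1oc2c([C@H]3CCN(C)C[C@H]3O)c(O)cc(O)c2c(=O)c1C(O)c1ccc(F)c(Br)c1` gives 9%, and a number 1 percentage points lower from compound 1 to compound 2 (within the scatter) stays within the scatter. Compound 3 `Cc1oc2c([C@H]3CCN(C)C[C@H]3O)c(O)cc(O)c2c(=O)c1C(O)c1c(F)cccc1Cl` gives 41%, the highest of the three numbers. Two large steps lead to it: a number 31 percentage points higher from compound 1 to compound 3 (beyond the scatter) and a number 32 percentage points higher from compound 2 to compound 3 (beyond the scatter).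

The unmeasured compound 4 `Cc1oc2c([C@H]3CCN(C)C[C@H]3O)c(O)cc(O)c2c(=O)c1C(O)c1csc([N+](=O)[O-])c1` keeps the shared core and differs from compound 3 in one place: 5-nitrothiophen-3-yl in place of 2-chloro-6-fluorophenyl on a saturated chain carbon bound to an aromatic carbon and an oxygen on a saturated carbon. Here 5-nitrothiophen-3-yl stands in place of 2-chloro-6-fluorophenyl on a saturated chain carbon bound to an aromatic carbon and an oxygen on a saturated carbon.

All three measured steps change this same place, so all three bear on the new one. They show that a swap here can mean a large step or none beyond the scatter. None of them brings in a five-membered aromatic ring, so the data give no direct reading of the entering group. With compound 3 set apart from compound 2 by a number 32 percentage points higher from compound 2 to compound 3 (beyond the scatter), the expectation leans back towards the lower pair. A clear fall of moderate size is expected, with the estimated step of a number 21 percentage points lower from compound 3 to compound 4 (beyond the scatter). The estimate for compound 4 is 20%, with an expected range of 5% to 42%.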

Compound 4, percent growth inhibition at one concentration: 41%
Beside the measured number, compound 4's estimate is 21 percentage points below it, and the stated range covers the measured number.
By their numbers in this assay, from the lowest: compounds 2 and 1 (each within the scatter of the next); then compounds 3 and 4 (each within the scatter of the next).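

In this assay, 5-nitrothiophen-3-yl in place of 2-chloro-6-fluorophenyl gives no change at the digits printed from compound 3 to compound 4 (within the scatter), so at this place, on a saturated chain carbon bound to an aromatic carbon and an oxygen on a saturated carbon, the higher level is not confined to a six-membered aromatic ring of carbon only or to a halogen-bearing group. The same group also separates from the lower pair, with a number 32 percentage points higher from compound 2 to compound 4 (beyond the scatter) and a number 31 percentage points higher from compound 1 to compound 4 (beyond the scatter), so the large steps here no longer rest on 2-chloro-6-fluorophenyl alone, while the halogen-bearing groups of compound 1 and compound 2 show that a halogen-bearing ring does not by itself give the higher level. Nothing on hand accounts for two such different groups reading alike.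

The compounds shown leave open whether the reading belongs to the five-membered aromatic ring or to the nitro group, and how an amine or a carboxylic acid in place of the nitro group would read. They also leave open whether compound 3 and compound 4 would separate at other concentrations, since the series is read at a single concentration.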